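Furan-2-yl to furan-3-yl on a long-chain amide

This account rests on a few compounds, and the source may have more. Where it says the series, first, only, none or still open, it means among the compounds named here.

In a functional assay on LOX IMVI cells (Homo sapiens) for inhibition, read by colorimetric assay and sulforhodamine B assay, with a stated time of 48 h (on this read-out lower numbers stand for stronger inhibition of growth and higher numbers for weaker inhibition of growth), compound 1 `CCCCCCCCCCCC[C@@H](O)[C@H]1CC[C@H]([C@H](O)CCCCCCCCCCNC(=O)c2cccs2)O1` gives 1290 nM, and compound 2 `CCCCCCCCCCCC[C@@H](O)[C@H]1CC[C@H]([C@H](O)CCCCCCCCCCNC(=O)c2ccco2)O1` gives 17000 nM, the higher of the two numbers. Compound 3 `CCCCCCCCCCCC[C@@H](O)[C@H]1CC[C@H]([C@H](O)CCCCCCCCCCNC(=O)c2ccoc2)O1` differs from compound 2 by furan-3-yl in place of furan-2-yl on a carbonyl carbon. Within the data shown here, the only measured step bearing on this is a 13-fold higher number from compound 1 to compound 2 (1.12 log units; beyond the scatter), which is large but concerns a different exchange, furan-2-yl in place of thiophen-2-yl. The data therefore give no direct measure for this change, and only a modest shift toward lower numbers is expected. The estimated step is a 1.9-fold lower number from compound 2 to compound 3 (0.28 log units; within the scatter). Compound 3 is expected at 9000 nM, with an estimated range of 2500 nM to 30000 nM.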

Compound 3, concentration for 50% growth inhibition: 21900 nM
The estimate for compound 3 lay 2.4-fold (0.39 log units) below the measured number, and the stated range covers the measured number.
By their numbers in this assay, from the lowest: compound 1; then compounds 2 and 3 (each within the scatter of the next).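

In this assay the move of the furan attachment on the carbonyl carbon gives a 1.3-fold higher number from compound 2 to compound 3 (0.11 log units; within the scatter) and does not separate furan-2-yl from furan-3-yl. Thiophen-2-yl stands apart from this furan too, with a 17-fold higher number from compound 1 to compound 3 (1.23 log units; beyond the scatter) as the step, so the earlier gap does not hang on one furan attachment. Nothing among the data gives a reason for that gap. The compounds shown leave open whether thiophen-3-yl would fall with thiophen-2-yl or with the two furans, and where a phenyl group on the carbonyl carbon would stand.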